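Swapping the amino acid side chain in compound 4

The source may report more compounds than this note shows. Statements on the series, on what has been measured and on what is new or still open speak of the compounds shown alone.

Compound 1, `O=C(O)[C@@H]1CCCN1C(=O)CN(c1nc(Cl)nc2[nH]cnc12)C1CC1`: 26%
Compound 2, `C[C@@H](O)[C@H](NC(=O)CN(c1nc(Cl)nc2[nH]cnc12)C1CC1)C(=O)OCc1ccccc1`: 29.9%
Compound 3, `C[C@@H](O)[C@H](NC(=O)CN(c1nc(Cl)nc2[nH]cnc12)C1CC1)C(=O)O`: 35.9%

All three were measured in a functional assay on the whole organism (Tail, strain ICR) with Mus musculus as the target, in the tail flick test, with a stated time of 90 min, at a dose of 25 umol/kg by the oral route; a higher number here means a stronger effect of the compound at the dose given, a lower number a weaker effect. Compound 3 gives the highest of the three numbers, but this says little: the step of a number 9.9 percentage points higher from compound 1 to compound 3 (within the scatter) and the step of a number 6 percentage points higher from compound 2 to compound 3 (within the scatter) are both within the scatter, so the three compounds cannot be told apart on these numbers.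

Compound 4, `NC(=O)CC[C@H](NC(=O)CN(c1nc(Cl)nc2[nH]cnc12)C1CC1)C(=O)O`, differs from compound 3 in one place: 2-carbamoylethyl in place of 1-hydroxyethyl on a saturated chain carbon bound to an amide-type nitrogen and a carbonyl carbon. Among the compounds with values here, no measured pair changes this side chain. The closest comparison is the exchange of the whole amino acid portion between compound 1 and compound 3, which moved the read-out only within the scatter, and the change at the carboxylic acid between compound 2 and compound 3 was likewise small. With every known change in this series staying within the scatter, the step of a number 2.9 percentage points lower from compound 3 to compound 4 (within the scatter) is expected to be small as well, with no clear direction. Compound 4 is therefore estimated at 33%, within a range of 20% to 46%.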

Compound 4, a percentage reported as activity, at one dose (the size of the read-out at that dose, not a potency): 41.1%
For compound 4 the middle estimate is 8.1 percentage points below the measured one, within the range that was stated.
By their numbers in this assay, from the lowest: compounds 1, 2, 3 and 4 (each within the scatter of the next, the first and the last beyond it).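

In this assay, putting 2-carbamoylethyl in place of 1-hydroxyethyl on a saturated chain carbon bound to an amide-type nitrogen and a carbonyl carbon amounts to a number 5.2 percentage points higher from compound 3 to compound 4 (within the scatter). This is the only pair shown that changes this side chain alone, and it shows that a group of 5 heavy atoms can replace one of 3 heavy atoms, with its defined stereocentre, while the two compounds remain impossible to tell apart on this read-out. Nothing shown here explains why these two side chains read alike.

Still open, going by these compounds, is how this position would respond to a side chain ending in a carboxylic acid, such as 2-carboxyethyl, or in an amine, such as 4-aminobutyl. On these data alone, a plain methyl group at this place is an equally open case, marking the short end of the range of chains.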